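This account rests on a few compounds, and the source may have more. Where it says the series, first, only, none or still open, it means among the compounds named here.

Among the three measured compounds, compound 1 `[O-][n+]1nc(NCOC2CCCCC2)[n+]([O-])c2ccccc21` has the highest number in a functional assay on K562 cells (Homo sapiens) for cytotoxicity, read by MTT assay, with a stated time of 72 h; a lower number here means a stronger inhibitor, a higher number a weaker inhibitor: compound 1 gives 4880 nM. Compound 3 `[O-][n+]1nc(NCOCc2ccc(C(F)(F)F)cc2)[n+]([O-])c2ccccc21` gives 1240 nM, a gap beyond the usual scatter, and compound 2 `COc1ccc2c(c1)[n+]([O-])nc(NCOCc1ccccc1)[n+]2[O-]` gives 240 nM, further away still. Compound 4 `CCOCNc1n[n+]([O-])c2ccccc2[n+]1[O-]` has not yet been measured in this assay. It differs from compound 1 in one place: ethyl in place of cyclohexyl on an oxygen on a saturated carbon. Among the measured compounds shown here, no measured pair here shows what such a change does, so the expectation rests only on compound 1 and its value 4880 nM. The step of a 1.2-fold higher number from compound 1 to compound 4 (0.09 log units; within the scatter) is expected to be small, within the usual scatter, with at most a slight lean toward a higher number. Compound 4 is expected to give 6000 nM, with a range from 2000 nM to 18000 nM.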

Compound 4, half-maximal inhibitory concentration: 4990 nM
The estimate for compound 4 lay 1.2-fold (0.08 log units) above the measured number; the measured number falls inside the stated range.
By their numbers in this assay, from the lowest: compound 2; then compound 3; then compounds 1 and 4 (each within the scatter of the next).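

In this assay, ethyl in place of cyclohexyl on an oxygen on a saturated carbon gives a 1.0-fold higher number from compound 1 to compound 4 (0.01 log units; within the scatter). Among the compounds shown here, this is the first direct reading at this place: with the rest of the structure held the same, replacing the ring with this short open chain makes no difference that can be read beyond the scatter. Nothing shown here explains why the two groups read alike.

Still open, going by these compounds, is whether a longer chain, a primary amine or a carboxylic acid in this place would also leave the number within the scatter. Also open, on these data alone, is whether this exchange would read the same on a core with other substituents.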